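From compound 2 to compound 4: one added group

The source may hold more compounds than are shown below. What is called first, only, known or untested is meant among the compounds shown, and "the series" means these compounds.

In a functional assay on HT-29 cells (Homo sapiens) for inhibition, read by MTT assay, with a stated time of 72 h (on this read-out lower numbers stand for stronger inhibition and higher numbers for weaker inhibition), compound 1 (`COc1cc(NC(=O)/C=C/c2cccc(OCc3ccccc3)c2)cc(OC)c1OC`) gives 3600 nM and compound 3 (`C=C(Br)C(=O)Nc1cccc(/C=C/C(=O)Nc2cccc3ccccc23)c1`) gives 6500 nM in the same test. Compound 2 (`C=C(Br)C(=O)Nc1cccc(/C=C/C(=O)Nc2ccccc2)c1`) stands at 16600 nM and so holds the highest of the three numbers, which makes it the weakest inhibitor of the set. Both other compounds lie lower by more than the usual scatter.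

Compound 4 (`C=C(Br)C(=O)Nc1cccc(/C=C/C(=O)Nc2ccc(OC(F)(F)F)cc2)c1`) has not yet been measured. It departs from compound 2 by a single change (trifluoromethoxy in place of hydrogen on an aromatic carbon): trifluoromethoxy in place of hydrogen on an aromatic carbon, para to a large group.

Within the data shown here, no two measured compounds differ in only one place, so the data offer no direct step by which to size this change. The nearest guide is compound 3, whose value (6500 nM) lies beyond the scatter under that of compound 2, which shows that a lower number is within reach. On this slender ground a moderate fall in the number is expected, and the estimated move in this assay is a 2.4-fold lower number from compound 2 to compound 4 (0.38 log units; beyond the scatter) and would only just clear the scatter. For compound 4 the expected value is 7000 nM (estimated range 2500 nM to 16000 nM).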

Compound 4, half-maximal inhibitory concentration: 61200 nM
Estimate against measurement, compound 4: 8.7-fold (0.94 log units) below; the measured number lies above the stated range.
By their numbers in this assay, from the lowest: compounds 1 and 3 (each within the scatter of the next); then compound 2; then compound 4.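

In this assay, among these compounds, trifluoromethoxy in place of hydrogen on an aromatic carbon, para to a large group, gives a 3.7-fold higher number from compound 2 to compound 4 (0.57 log units; beyond the scatter), the first change in a single place that can be sized in this set. It shows that this position of compound 2 is not indifferent to substitution: adding this group of 5 heavy atoms moves the number upward, towards weaker inhibition, by more than the usual scatter. There is no measured information here that accounts for this shift.

One group at one place cannot show whether the rise belongs to trifluoromethoxy itself or to any addition there, and a fluorine atom, a methoxy group or an amine at the same place would help to separate those two readings. As far as these compounds go, it also remains open whether trifluoromethoxy on another carbon of the same ring, or on the core of compound 3, would move the number in the same direction.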